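Sulfonyl aryl swap on a second core: clearance notes

The source may report more compounds than this note shows. Statements on the series, on what has been measured and on what is new or still open speak of the compounds shown alone.

Compound 1 `COc1ccc(-c2c(S(=O)(=O)c3cccc(C#N)c3)cnc3cc(F)ccc23)cc1` and compound 2 `COc1ccc(-c2c(S(=O)(=O)c3ccc(F)c(F)c3)cnc3cc(F)ccc23)cc1` share one core; compound 3 `N#Cc1cccc(S(=O)(=O)c2cnc3c(F)cccc3c2-c2cccc(F)c2)c1` and compound 4 `O=S(=O)(c1ccc(F)c(F)c1)c1cnc2c(F)cccc2c1-c1cccc(F)c1` share another. The difference between the two cores is not broken down here. In an ADME assay on microsomes from liver (Homo sapiens) for metabolic stability, tested at 2.5 uM (a lower number here means slower removal, a higher number faster removal of the compound), compound 1 gives 0.92 mL/min and compound 2 gives 1.1 mL/min; the change 3,4-difluorophenyl in place of 3-cyanophenyl on a sulfonyl sulfur made a 1.2-fold higher number from compound 1 to compound 2 (0.08 log units; within the scatter). In this assay compound 3 gives 0.34 mL/min, the lowest of the three numbers. The change to compound 4, (3,4-difluorophenyl in place of 3-cyanophenyl on a sulfonyl sulfur), is the same change, on the same sulfonyl sulfur with an aromatic carbon as its other neighbour. Going by the values given here, for compound 4 the expected step is a 1.2-fold higher number from compound 3 to compound 4 (0.07 log units; within the scatter), resting on the single earlier instance, a 1.2-fold higher number from compound 1 to compound 2 (0.08 log units; within the scatter), which stayed within the scatter. Compound 4 is therefore estimated at 0.4 mL/min, between 0.25 mL/min and 0.65 mL/min.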

Compound 4, intrinsic clearance in a liver preparation (reported as CLH), per the amount of preparation that the assay uses: 1.28 mL/min
Compound 4: middle estimate off by 3.2-fold (0.51 log units), on the low side, and the stated range ends below it.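

In this assay, 3,4-difluorophenyl in place of 3-cyanophenyl on a sulfonyl sulfur gave a 3.8-fold higher number from compound 3 to compound 4 (0.58 log units; beyond the scatter). The step did not carry over unchanged from one core to the other: the same change on two cores in this assay, a 1.2-fold higher number (0.08 log units; within the scatter) from compound 1 to compound 2 and a 3.8-fold higher number (0.58 log units; beyond the scatter) from compound 3 to compound 4, 3.1-fold (0.50 log units) apart, beyond the scatter of two such steps. With one pair on each core, this shows that the size of the step cannot be assumed to transfer between these two cores, but it does not show which part of the core difference goes with the larger step.

Going by these compounds, whether a further core would follow the small step or the large one remains open. Also open, on these data alone, is how an amine or a carboxylic acid in place of 3-cyanophenyl would behave on either core.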